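Replacing isobutyl with pyridin-3-yl on the chain carbon

A few compounds are considered here, and "the series" means these few. Any claim that something is new, unique, unknown or untested is made for them only; others in the source may bear on it.

Compound 1 `C/C(=C\C(=O)Nc1ccccc1OCCCC(=O)O)c1ccc2c(ccn2C(C)c2ccccc2)c1`: 19 nM in an assay on Prostate gland for inhibition of steroid 5-alpha-reductase (Rattus norvegicus); a higher number here means a weaker inhibitor, a lower number a stronger inhibitor
Compound 2 `C/C(=C\C(=O)Nc1ccccc1OCCCC(=O)O)c1ccc2c(ccn2C(CC(C)C)c2ccccc2)c1`: 6.3 nM in this assay

For the measured compounds named here, compound 2 holds the lower of the two numbers, and the one step seen so far is a 3.0-fold lower number from compound 1 to compound 2 (0.48 log units; beyond the scatter). Compound 3 `C/C(=C\C(=O)Nc1ccccc1OCCCC(=O)O)c1ccc2c(ccn2C(c2ccccc2)c2cccnc2)c1` differs from compound 2 by pyridin-3-yl in place of isobutyl on a saturated chain carbon bound to an aromatic carbon and an aromatic nitrogen. Going by the values given here, that earlier step added bulk at the same chain carbon, so it bears only loosely on trading a chain for an aromatic ring there; no step shows a ring at this spot. A change within the scatter in this assay is expected. Compound 3 is therefore estimated at 8 nM, between 3 nM and 25 nM. The expected step is a 1.3-fold higher number from compound 2 to compound 3 (0.10 log units; within the scatter).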

Compound 3, half-maximal inhibitory concentration: 47 nM
Beside the measured number, compound 3's estimate is 5.9-fold (0.77 log units) below it; the whole stated range lies below it.
By their numbers in this assay, from the lowest: compound 2; then compound 1; then compound 3.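

Pyridin-3-yl is tolerated on this chain carbon but ranks last of the three groups seen there in this assay, with a 7.5-fold higher number from compound 2 to compound 3 (0.87 log units; beyond the scatter) and a 2.5-fold higher number from compound 1 to compound 3 (0.39 log units; beyond the scatter). A larger group therefore does not by itself bring a lower number here: isobutyl did, whereas pyridin-3-yl did not. Nothing available explains this rise.

On these data alone, whether the ring as a whole or its nitrogen matters remains open, and phenyl on this carbon could separate the two. Whether a longer chain, such as n-hexyl, lowers the number further is also unresolved.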